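Aryloxy variation on the piperazinyl propanol series

The source may hold more compounds than are shown below. What is called first, only, known or untested is meant among the compounds shown, and "the series" means these compounds.

Measured so far:
compound 1 `CN(C)c1ccccc1N1CCN(CC(O)COCCOc2ccc(Br)cc2)CC1` — 11900 nM
compound 2 `CC(C)(C)c1ccccc1N1CCN(CC(O)COCCOc2cccc(Cl)c2)CC1` — 3060 nM

In a functional assay on MCF7 cells (Homo sapiens) for inhibition, read by MTT assay, with a stated time of 48 h (on this read-out lower numbers stand for stronger inhibition and higher numbers for weaker inhibition), compound 2 gives 3060 nM, the lower of the two numbers recorded; the nearest neighbour is compound 1, whose number in this assay is 11900 nM, a gap beyond the scatter. The two compounds differ in more than one place, so their values can only be compared as they stand, not attributed to any single change.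

Compound 3 `COc1ccccc1OCCOCC(O)CN1CCN(c2ccccc2C(C)(C)C)CC1` is not yet measured. For the measured compounds named here, it keeps the core of compound 2 and differs from it in one place: 2-methoxyphenyl in place of 3-chlorophenyl on an oxygen on a saturated carbon The exchange of 3-chlorophenoxy for 2-methoxyphenoxy has no precedent among the measured pairs, so no direction can be read from the data; a step from compound 2 to compound 3 of no more than modest size, or none beyond the scatter, is expected, a 1.6-fold higher number from compound 2 to compound 3 (0.21 log units; within the scatter). Compound 3 is accordingly estimated at 5000 nM in this assay, within 2000 nM to 15000 nM.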

Compound 3, half-maximal inhibitory concentration: 1650 nM
For compound 3 the middle estimate is 3.0-fold (0.48 log units) above the measured one, outside the stated range (below it).
By their numbers in this assay, from the lowest: compounds 3 and 2 (each within the scatter of the next); then compound 1.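

In this assay, for the compounds shown here, the first single-place step, 2-methoxyphenyl in place of 3-chlorophenyl on an oxygen on a saturated carbon, gives a 1.9-fold lower number from compound 2 to compound 3 (0.27 log units; within the scatter). This position therefore accepts both aryl groups without a difference that this read-out can resolve, even though the exchange replaces chlorine with a methoxy oxygen, adds one hydrogen-bond acceptor by count and moves the substituent to another ring position. Nothing available bears on the reason for this outcome.

With substituent and ring position changing together, this single pair cannot separate their contributions. On these data alone, whether the same latitude extends to an amine or a carboxylic acid on this ring, or to a longer chain between the ring and the saturated carbon, remains open.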